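This account rests on a few compounds, and the source may have more. Where it says the series, first, only, none or still open, it means among the compounds named here.

Compound 1 `COc1ccccc1/C=c1/[nH]c(=O)/c(=C\c2cccc(Cl)c2Cl)[nH]c1=O`, compound 2 `C=CCn1c(=O)/c(=C\c2cc(Br)ccc2F)[nH]c(=O)/c1=C\c1ccccc1OC` and compound 3 `COc1ccccc1/C=c1\c(=O)[nH]/c(=C/c2ccccc2Cl)c(=O)n1C` share one core and differ in the group on the amide nitrogen and in the substituents on one of the two aryl rings. In a functional assay on U-937 cells (Homo sapiens) for cytotoxicity, read by CCK-8 assay, with a stated time of 72 h (on this read-out higher numbers stand for weaker inhibition and lower numbers for stronger inhibition), compound 1 is reported as "not active" (no number reported). In this assay compound 3 gives 100 nM. In this assay compound 2 gives 4700 nM, the higher of the two numbers reported, and the gap to compound 3 lies well beyond the usual scatter.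

Compound 4 `C=CCn1c(=O)/c(=C\c2ccccc2F)[nH]c(=O)/c1=C\c1ccccc1OC` has not been measured. It differs from compound 2 in one place only: hydrogen in place of bromo on an aromatic carbon. Among the compounds with values here, no pair among the measured compounds isolates this change, so there is no directly comparable step to lean on. The expectation is therefore a modest step from compound 2 to compound 4, estimated as a 1.3-fold lower number from compound 2 to compound 4 (0.13 log units; within the scatter), most likely toward a somewhat lower number, but not clearly beyond the scatter. On that basis compound 4 is expected to give about 3500 nM in this assay, with a plausible range from 1000 nM to 12000 nM.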

Compound 4, half-maximal inhibitory concentration: 5500 nM
Beside the measured number, compound 4's estimate is 1.6-fold (0.20 log units) below it, and the stated range covers the measured number.
By their numbers in this assay, from the lowest: compound 3; then compounds 2 and 4 (each within the scatter of the next).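

In this assay, going from the 5-bromo-2-fluorophenyl group to the 2-fluorophenyl group gives a 1.2-fold higher number from compound 2 to compound 4 (0.07 log units; within the scatter), so the two compounds cannot be told apart on this read-out. Within the data shown here, this is the first comparison here that isolates a single change, and it shows that, with the rest of compound 2 kept in place, bromo and hydrogen at this position on the aromatic ring read the same within the usual scatter; the bromo is not needed to hold this level of activity, and losing it brings no clear gain. Nothing available here bears on why this swap leaves the read-out in the same place.

Bromo and hydrogen are the only two groups compared at this position, so it remains open whether an amine or a carboxylic acid there would read the same or would move the number clearly beyond the scatter. As far as these compounds go, it also remains open whether the bromo-to-hydrogen swap would read the same with the different group on the amide nitrogen that compound 3 carries.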